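Hydroxy in place of fluoro on the ethyl ester

This account rests on a few compounds, and the source may have more. Where it says the series, first, only, none or still open, it means among the compounds named here.

Measured in a functional assay on the whole organism (strain Sprague-Dawley) for inhibition, with Rattus norvegicus as the target, with a stated time of 10 min; a lower number here means that less compound is needed, a higher number that more compound is needed for the effect:
- compound 1 `O=C(O)c1cnc(-c2ccccc2F)[nH]c1=O`: 5 mg/kg
- compound 2 `C=CCc1cccc(-c2ncc(C(=O)O)c(=O)[nH]2)c1O`: > 0.5 mg/kg
- compound 3 `CCOC(=O)c1cnc(-c2ccccc2F)[nH]c1=O`: > 10 mg/kg

Compound 3 has no exact number, only a limit of > 10 mg/kg. Compound 2 also has only a limit, > 0.5 mg/kg, although it carries a hydroxy group on its aromatic ring.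

Compound 4 `CCOC(=O)c1cnc(-c2ccccc2O)[nH]c1=O` differs from compound 3 by one change: hydroxy in place of fluoro on an aromatic carbon. Within the data shown here, the sole measured step, an at least 2.0-fold higher number from compound 1 to compound 3 (0.30 log units; that floor lies within the scatter), concerns the ethyl group and not this change. It gives no size for the fluoro to hydroxy exchange, so no step beyond the scatter is expected in this assay, in either direction. The estimated step is a step that the limit leaves unreadable from compound 3 to compound 4. The estimate for compound 4 is 12 mg/kg, with an expected range from 3 mg/kg to 40 mg/kg.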

Compound 4, dose for 50% inhibition: 5 mg/kg
Compound 4: middle estimate off by 2.4-fold (0.38 log units), on the high side; the measured number falls inside the stated range.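

In this assay, hydroxy in place of fluoro on an aromatic carbon, ortho to a large group, gives an at least 2.0-fold lower number from compound 3 to compound 4 (0.30 log units; that floor lies within the scatter) on the ethyl ester. With hydroxy at this place, compound 4 reads 5 mg/kg as an exact number, so this ester now has a measured value. Compound 3 holds only a limit: the limit of > 10 mg/kg in this assay, at which 1 of the 4 values shown sits.

As far as these compounds go, the true size of the step therefore stays open, and it may exceed this floor. Also open, from the compounds shown here alone, is how a methoxy group or an amine at the same place would compare with the hydroxy of compound 4.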